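Thiophene in place of methyl on a pyrazolopyridinone-free shared core

This account rests on a few compounds, and the source may have more. Where it says the series, first, only, none or still open, it means among the compounds named here.

Measured so far:
compound 1 `Cc1cc2[nH]nc(N)c2c(=O)[nH]1` — 30%
compound 2 `COc1cccc(-c2cc3[nH]nc(N)c3c(=O)[nH]2)c1` — 56%

Both compounds were tested in an assay on isolated protein for inhibition of MAP kinase-activated protein kinase 2 (Homo sapiens), read by mobility shift assay, tested at 30 uM; a lower number here means less inhibition, a higher number more inhibition at the concentration tested (going by the name of the read-out). Compound 1 gives 30%, the lower of the two numbers. Compound 2 gives 56%, a value that lies above that of compound 1 by more than the usual scatter. Going by the values given here, no pair of these two differs in only one place, so the two values are simply reported side by side.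

Compound 3 `Nc1n[nH]c2cc(-c3cccs3)[nH]c(=O)c12` has not yet been measured in this assay. It differs from compound 1 by thiophen-2-yl in place of methyl on an aromatic carbon. Since compound 2, which also carries an aromatic ring, gives 56%, an increase is expected: the step of a number 20 percentage points higher from compound 1 to compound 3 (beyond the scatter) is estimated to lie beyond the scatter. Compound 3 is thus expected to give about 50%, with a range from 30% to 70%.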

Compound 3, a percentage reported as inhibition, at one concentration (the size of the read-out at that concentration, not a potency): 58%
Estimate against measurement, compound 3: 8 percentage points below, and the stated range covers the measured number.
By their numbers in this assay, from the lowest: compound 1; then compounds 2 and 3 (each within the scatter of the next).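

In this assay, thiophen-2-yl in place of methyl on the aromatic carbon next to the ring nitrogen gives a number 28 percentage points higher from compound 1 to compound 3 (beyond the scatter). Going by these compounds alone, this is the first comparison in which only one place changes, so the difference can be assigned to this exchange of groups rather than to any other part of the structure. It shows that the number in this assay is higher with a five-membered aromatic ring with a sulfur atom at this place than with a single carbon. Nothing measured here explains the rise. The compounds shown leave open whether the sulfur atom matters, which furan-2-yl at the same place could test. They also leave open whether an amine or a longer alkyl chain there would give a similar number.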